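The source may hold more compounds than are shown below. What is called first, only, known or untested is meant among the compounds shown, and "the series" means these compounds.

Working notes on the series, read in a functional assay on K562 cells (Homo sapiens) for antiproliferative activity; on this read-out higher numbers stand for weaker inhibition and lower numbers for stronger inhibition. Compound 1 `Cc1c(F)c(=O)[nH]c(=O)n1C1O[C@H](CO)[C@@H](O)[C@H]1O` gives > 10 ug/mL, which is a limit of the assay and not a number. Compound 2 `O=c1cc(CO)n(C2O[C@H](CO)[C@@H](O)[C@H]2O)c(=O)[nH]1` gives > 10 ug/mL, which is likewise a limit and not a number. The data so far amount to the limit of > 10 ug/mL in this assay, at which 2 of the 2 values shown sit, so compound 2 has no exact place in the series and no order can be drawn for the two compounds.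

The next compound to be read is compound 3 `O=c1cc(CF)n(C2O[C@H](CO)[C@@H](O)[C@H]2O)c(=O)[nH]1`. The change is fluoro in place of hydroxy on a saturated chain carbon bound to an aromatic carbon, or hydroxymethyl to fluoromethyl. Among the measured compounds shown here, no measured step covers this change, so the only anchor is the limit of compound 2 at > 10 ug/mL. On that basis, no shift beyond the usual scatter is expected, and no direction is favoured. The expected step is a step that the limit leaves unreadable from compound 2 to compound 3. The estimate for compound 3 is 15 ug/mL, with an expected range of 4 ug/mL to 40 ug/mL.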

Compound 3, half-maximal inhibitory concentration: > 10 ug/mL
Compound 3 was reported as a limit (the forecaster's own chance of this, stated with the estimate: 75%); the middle value does not contradict the limit.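

In this assay compound 3 gives > 10 ug/mL, again a limit and not a number. No step can be read between compound 2 and compound 3, so the change from hydroxymethyl to fluoromethyl has no readable size. The compounds shown leave open any exact potency and any order among them: the limit of > 10 ug/mL in this assay, at which 3 of the 3 values shown sit.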